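This account rests on a few compounds, and the source may have more. Where it says the series, first, only, none or still open, it means among the compounds named here.

Compounds measured in an in vitro ADME assay on microsomes from liver (Homo sapiens) for pharmacokinetics, read by LC-MS, with a stated time of 10 min, tested at 1 uM; a lower number here means slower removal, a higher number faster removal of the compound:
compound 1 `CN1C[C@H](C(=O)Nc2ccc(F)cc2)[C@@H](c2ccc(/C=C/C(=O)Nc3ccccc3N)cc2)C1`, 5 mL/min/kg;
compound 2 `CC(C)c1ccc(NC(=O)[C@H]2CN(C)C[C@@H]2c2ccc(/C=C/C(=O)Nc3ccccc3N)cc2)cc1`, 10 mL/min/kg;
compound 3 `Cc1cccc(NC(=O)[C@H]2CN(C)C[C@@H]2c2ccc(/C=C/C(=O)Nc3ccccc3N)cc2)c1`, 14 mL/min/kg.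

Compound 3 gives the highest of the three numbers in this assay, its nearest neighbour being compound 2 and its furthest compound 1. Compound 4 `CN1C[C@H](C(=O)Nc2ccc(Cl)cc2F)[C@@H](c2ccc(/C=C/C(=O)Nc3ccccc3N)cc2)C1` differs from compound 3 in one place: 4-chloro-2-fluorophenyl in place of 3-methylphenyl on an amide-type nitrogen. The step that bears on this change is a 2.8-fold higher number from compound 1 to compound 3 (0.45 log units; beyond the scatter), since compound 1 also carries a fluorine-bearing phenyl on that nitrogen; the step of a 2.0-fold higher number from compound 1 to compound 2 (0.30 log units; within the scatter) points the same way. Reversing that direction, a modest drop in this assay is expected for compound 4, roughly a 2.0-fold lower number from compound 3 to compound 4 (0.30 log units; within the scatter), giving an estimated 7 mL/min/kg with a range of 3.5 mL/min/kg to 14 mL/min/kg.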

Compound 4, clearance: 11 mL/min/kg
Estimate against measurement, compound 4: 1.6-fold (0.20 log units) below; the measured number falls inside the stated range.
By their numbers in this assay, from the lowest: compounds 1, 2, 4 and 3 (each within the scatter of the next, the first and the last beyond it).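

In this assay, 4-chloro-2-fluorophenyl on the amide-type nitrogen stays level with 3-methylphenyl (a 1.3-fold lower number from compound 3 to compound 4 (0.10 log units; within the scatter)) and with 4-isopropylphenyl (a 1.1-fold higher number from compound 2 to compound 4 (0.04 log units; within the scatter)), yet it separates from 4-fluorophenyl (a 2.2-fold higher number from compound 1 to compound 4 (0.34 log units; beyond the scatter)). A fluorine on this phenyl therefore does not by itself go with the low number of compound 1. Nothing shown gives a reason for this.

Open, going by these compounds, is how the chlorine and the fluorine of compound 4 each contribute, and whether a pyridine ring or a phenyl carrying an amine would stay with compounds 2, 3 and 4.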